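From methoxy to (4-chlorobenzyl)oxy on compound 1

A few compounds are considered here, and "the series" means these few. Any claim that something is new, unique, unknown or untested is made for them only; others in the source may bear on it.

Compound 1 (`COc1ccc(OCCOCCNC2CCCC2)cc1`) gives 99100 nM in a functional assay on SK-OV-3 cells (Homo sapiens) for inhibition, read by CCK-8 assay, with a stated time of 70 h (a lower number here means a stronger inhibitor, a higher number a weaker inhibitor), and compound 2 (`OCCOCCOCCOc1ccc(OCc2ccccc2)cc1`) gives 59400 nM there, so the two stand within the scatter of each other. Within the data shown here, compound 3 (`Clc1ccc(COc2ccc(OCCOCCNC3CCCC3)cc2)cc1`) keeps the core of compound 1 and has 4-chlorophenyl in place of hydrogen on a saturated chain carbon bound to an oxygen on an aromatic ring as its only change. Among the measured compounds shown here, no measured step covers this change, so the expectation in this assay rests on the structural change alone. An estimated step of a 5.0-fold lower number from compound 1 to compound 3 (0.70 log units; beyond the scatter) toward a lower number is expected, beyond the scatter. Compound 3 is estimated at 20000 nM with an expected range of 6000 nM to 60000 nM in this series.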

Compound 3, half-maximal inhibitory concentration: 7670 nM
Estimate against measurement, compound 3: 2.6-fold (0.42 log units) above, and the stated range covers the measured number.
By their numbers in this assay, from the lowest: compound 3; then compounds 2 and 1 (each within the scatter of the next).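

In this assay, among these compounds, the change from methoxy to (4-chlorobenzyl)oxy gives a 13-fold lower number from compound 1 to compound 3 (1.11 log units; beyond the scatter), the first step and one beyond the scatter. The place on the saturated chain carbon bound to an oxygen on an aromatic ring therefore accepts 4-chlorophenyl, and the number there responds strongly to it. Nothing measured here accounts for the size of this step.

As far as these compounds go, whether 4-fluorobenzyl or 4-methoxybenzyl would give a similar step remains open. So does whether a longer chain between the oxygen and the 4-chlorophenyl would keep it.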